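Chloro for Methoxy on the Triazole-Linked Aryl Ring

The source may hold more compounds than are shown below. What is called first, only, known or untested is meant among the compounds shown, and "the series" means these compounds.

Measured compounds:
- Compound 1, `C=C1C(=O)[C@]23C[C@@]1(O)CC[C@H]2c1ccc(OS(=O)(=O)c2ccc(C)cc2)c(C)c1[C@@H]3Cn1cc(-c2ccccn2)nn1`, gives 2310 nM in a functional assay on A549 cells (Homo sapiens) for cytotoxicity, read by MTT assay, with a stated time of 4 days; a lower number here means a stronger inhibitor, a higher number a weaker inhibitor.
- Compound 2, `C=C1C[C@]23C[C@@]1(O)CC[C@@H]2c1cccc(C)c1[C@@H]3Cn1cc(-c2ccc(OC)cc2)nn1`, gives > 20000 nM in this assay, which is a limit of the assay and not a number.

Within the data shown here, of the two values shown, compound 1 is the only one reported as a number. Compound 2 sits at the assay limit, (the limit of > 20000 nM in this assay, at which 1 of the 2 values shown sits), so its standing can only be given as a range beyond that point. Among the measured compounds shown here, compound 1 and compound 2 differ in several places at once, so no single step between them is available, and nothing more can be said of the pair than what the two values show.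

Compound 3, `C=C1C[C@]23C[C@@]1(O)CC[C@@H]2c1cccc(C)c1[C@@H]3Cn1cc(-c2ccc(Cl)cc2)nn1`, has not yet been measured in this assay. It differs from compound 2 in one place: chloro in place of methoxy on an aromatic carbon.

For the measured compounds named here, no measured step shows what this exchange does in this assay. With compound 2 already at the assay limit, the step from compound 2 to compound 3 is expected to be a step that the limit leaves unreadable from compound 2 to compound 3, that is, none beyond the usual scatter. Compound 3 is therefore expected to give about 25000 nM, within 8000 nM to 80000 nM, with a real chance that only a limit is reported again.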

Compound 3, half-maximal inhibitory concentration: > 20000 nM
Compound 3: only a limit was reported (the forecaster's own chance of this, stated with the estimate: 60%); the middle value does not contradict the limit.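

Compound 2 and compound 3 each give only a limit of the assay in this assay, so no step can be read for chloro in place of methoxy: the limit of > 20000 nM in this assay, at which 2 of the 3 values shown sit.

The compounds shown leave open whether 4-methoxyphenyl and 4-chlorophenyl differ at all in this assay, and which of the several differences between compound 1 and compound 2 matters.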